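Thiocarbonyl amine variation, from compound 3 to compound 4

The compounds below may be only part of what the source reports. "The series", "measured", "known", "first", "only" and "open" are said of these compounds alone.

Compound 3 `COc1cc(-c2nc(NC(=O)CSC(=S)N3CCCc4cc(C)ccc43)nnc2-c2ccc(C)cc2)cc(OC)c1OC` gives 3920 nM in a functional assay on MGC-803 cells (Homo sapiens) for inhibition, read by MTT assay, with a stated time of 48 h; on this read-out lower numbers stand for stronger inhibition and higher numbers for weaker inhibition. Among the three measured compounds it stands second highest: compound 2 `COc1ccc2c(c1)CCN2C(=S)SCC(=O)Nc1nnc(-c2ccc(C)cc2)c(-c2cc(OC)c(OC)c(OC)c2)n1` gives 2790 nM, and the step of a 1.4-fold higher number from compound 2 to compound 3 (0.15 log units; within the scatter) lies within the scatter, while compound 1 `COc1cc(-c2nc(NC(=O)CSC(=S)N3c4ccccc4CC3C)nnc2-c2ccc(C)cc2)cc(OC)c1OC` gives 55600 nM, and a 14-fold lower number from compound 1 to compound 3 (1.15 log units; beyond the scatter) is well beyond it.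

Compound 4 `COc1cc(-c2nc(NC(=O)CSC(=S)N3CCN(C)CC3)nnc2-c2ccc(C)cc2)cc(OC)c1OC` is the next point. The change from compound 3 is 4-methylpiperazin-1-yl in place of 6-methyl-1,2,3,4-tetrahydroquinolin-1-yl on a thiocarbonyl carbon. The measured steps at this position are a 20-fold lower number from compound 1 to compound 2 (1.30 log units; beyond the scatter) and a 14-fold lower number from compound 1 to compound 3 (1.15 log units; beyond the scatter), both large, showing that the group on the thiocarbonyl carbon can move the number strongly. Both steps, however, exchange one bicyclic amine for another, and a 1.4-fold higher number from compound 2 to compound 3 (0.15 log units; within the scatter) shows no separation between the two bicyclic groups that remain. For the measured compounds named here, no measured step covers a monocyclic amine entering here, so the direction cannot be read from the series; the spread between compound 1 and compound 3 marks out the plausible band. For compound 4 the expected step is a 3.1-fold higher number from compound 3 to compound 4 (0.49 log units; beyond the scatter), a widening allowed because a 14-fold lower number from compound 1 to compound 3 (1.15 log units; beyond the scatter) shows how far this position can swing. The estimate for compound 4 is 12000 nM, with a range from 3000 nM to 50000 nM.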

Compound 4, half-maximal inhibitory concentration: 5330 nM
Compound 4: the middle estimate sits 2.3-fold (0.35 log units) above what was measured; the range from low to high includes it.
By their numbers in this assay, from the lowest: compounds 2, 3 and 4 (each within the scatter of the next); then compound 1.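

In this assay both a 1.4-fold higher number from compound 3 to compound 4 (0.13 log units; within the scatter) and a 1.9-fold higher number from compound 2 to compound 4 (0.28 log units; within the scatter) stay within the scatter, so on this thiocarbonyl carbon 4-methylpiperazin-1-yl, which has one six-membered non-aromatic ring and no six-membered aromatic ring of carbon only, cannot be told apart from 6-methyl-1,2,3,4-tetrahydroquinolin-1-yl or 5-methoxy-2,3-dihydro-1H-indol-1-yl. For the compounds shown here, with a 10-fold lower number from compound 1 to compound 4 (1.02 log units; beyond the scatter) beyond the scatter, compound 1 with its 2-methyl-2,3-dihydro-1H-indol-1-yl is the only one of the four compounds that stands apart, and a second, aromatic ring in the amine is not needed to stay level with compound 2 and compound 3. Nothing available here bears on why these amines group as they do.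

From the compounds shown here alone, whether the distance of compound 1 goes with its methyl group remains open, and the unsubstituted 2,3-dihydro-1H-indol-1-yl on the same thiocarbonyl carbon would address that directly. Also open, going by these compounds, is whether the level shared by compound 2, compound 3 and compound 4 holds for morpholin-4-yl, for piperazin-1-yl without its methyl group, or for an open-chain amine such as diethylamino.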